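Swapping an ester for a ketone on a cell-growth core

A few compounds are considered here, and "the series" means these few. Any claim that something is new, unique, unknown or untested is made for them only; others in the source may bear on it.

Of the compounds shown here, three have been tested in a functional assay on MCF7 cells (Homo sapiens) for inhibition, read by sulforhodamine B assay, with a stated time of 48 h; a lower number here means a stronger inhibitor of growth, a higher number a weaker inhibitor of growth. Compound 1 `C=C(C)[C@@H]1CC=C(Cn2cc(COc3cccc(C4NC(=O)NC(C)=C4C(=O)OCC)c3)nn2)CC1` gives 42500 nM in this assay. Compound 3 `C=C(C)[C@@H]1CC=C(Cn2cc(COc3cccc(C4NC(=O)NC(C)=C4C(C)=O)c3)nn2)CC1` gives 43000 nM in this assay. The difference between compound 1 and compound 3 is a small one: methyl in place of ethoxy on a carbonyl carbon. That change produced a 1.0-fold higher number from compound 1 to compound 3 (0.01 log units; within the scatter), so the two numbers cannot be told apart.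

Compound 2 `C=C(C)[C@@H]1CC=C(Cn2cc(COc3ccccc3C3NC(=O)NC(C)=C3C(=O)OCC)nn2)CC1` has the same atoms as compound 1 joined in a different way; how its core differs from that of compound 1 is not broken down here. For compound 2 this assay returned only a limit, > 100000 nM, not a number.

Compound 4 `C=C(C)[C@@H]1CC=C(Cn2cc(COc3ccccc3C3NC(=O)NC(C)=C3C(C)=O)nn2)CC1` is to compound 2 what compound 3 is to compound 1: methyl in place of ethoxy on a carbonyl carbon. Because the measured version of this change, a 1.0-fold higher number from compound 1 to compound 3 (0.01 log units; within the scatter), stayed within the scatter, the same change is expected to leave compound 4 close to compound 2, with an expected step of a number no higher from compound 2 to compound 4 (the limit leaves the size open). Because compound 2 sits at the limit of > 100000 nM in this assay, at which 1 of the 3 values shown sits, the most likely outcome is that compound 4 is also reported as a limit rather than a number. If a number does come out, compound 4 is estimated at 100000 nM, between 50000 nM and 300000 nM.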

Compound 4, concentration for total growth inhibition: 68700 nM
Compound 4: the middle estimate sits 1.5-fold (0.16 log units) above what was measured, within the range that was stated.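

Compound 2 gives > 100000 nM in this assay, which is a limit of the assay and not a number. From the compounds shown here alone, measured against that limit, the change from ethoxycarbonyl to acetyl gives an at least 1.4-fold lower number from compound 2 to compound 4 (0.16 log units; that floor lies within the scatter), so neither core shows a step beyond the scatter, while the true size of the step on the core of compound 2 stays unknown. Set side by side, the two steps do not settle whether this change carries over unchanged from one core to the other: the same change on two cores in this assay, a 1.0-fold higher number (0.01 log units; within the scatter) from compound 1 to compound 3 and an at least 1.4-fold lower number (0.16 log units; that floor lies within the scatter) from compound 2 to compound 4; the limit leaves it open whether they differ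

The compounds shown carry only ethoxy or methyl on this carbonyl carbon, which leaves open what an amine, forming an amide there, a hydroxyl, forming a carboxylic acid, or a chain longer than ethoxy would do on either core. Also open, going by these compounds, is how far the true value of compound 2 lies past its limit, and with it whether the ketone on this core truly differs from the ester.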